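Carboxy in place of cyano on compound 2

The compounds below may be only part of what the source reports. "The series", "measured", "known", "first", "only" and "open" are said of these compounds alone.

Going by the values given here, in a functional assay for inhibition, with Homo sapiens as the target (a lower number here means a stronger inhibitor, a higher number a weaker inhibitor), compound 1 `CC(C)(O)c1cc(-c2ccccc2)c2ccc(OCc3cccc(C4(O)CCOCC4)c3)cc2c1` gives 59 nM, and compound 2 `N#Cc1cc(-c2ccccc2)c2ccc(OCc3cccc(C4(O)CCOCC4)c3)cc2c1` gives 3 nM, the lower of the two numbers so far. The next structure is compound 3 `O=C(O)c1cc(-c2ccccc2)c2ccc(OCc3cccc(C4(O)CCOCC4)c3)cc2c1`, which differs from compound 2 as follows: carboxy in place of cyano on an aromatic carbon. Among the compounds with values here, only one measured step bears on this change: a 20-fold lower number from compound 1 to compound 2 (1.29 log units; beyond the scatter), also made at this aromatic carbon and large. Within the data shown here, it shows that the number can move well beyond the scatter with the group at this place, though no carboxy compound has yet been measured. Compound 2 also holds the lowest number, so leaving cyano is expected to raise the number, by an amount similar to that one step. The expected change is a 40-fold higher number from compound 2 to compound 3 (1.60 log units; beyond the scatter), which would lie beyond the scatter. For compound 3 the estimated value is 120 nM, with an expected range of 20 nM to 800 nM.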

Compound 3, half-maximal inhibitory concentration: 190 nM
For compound 3 the middle estimate is 1.6-fold (0.20 log units) below the measured one; measured number inside the range.
By their numbers in this assay, from the lowest: compound 2; then compound 1; then compound 3.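

In this assay, this aromatic carbon does not simply accept any polar-looking replacement for cyano: carboxy in place of cyano gives a 63-fold higher number from compound 2 to compound 3 (1.80 log units; beyond the scatter), a large step that reverses the gain seen earlier with cyano. Carboxy in place of 1-hydroxy-1-methylethyl gives a 3.2-fold higher number from compound 1 to compound 3 (0.51 log units; beyond the scatter), a modest step, so the order at this place now runs cyano, 1-hydroxy-1-methylethyl, carboxy, with cyano well apart from the other two. No measured property of these groups is available to account for this order.

Going by these compounds, whether a primary amide, a methyl ester or an aminomethyl group at this carbon would fall nearer to cyano or to carboxy remains open. On these data alone, all three compounds also carry the same phenyl group and the same remainder of the core, so it is open whether the order holds with a different group in place of that phenyl.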